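Swapping the butyl chain for phenethyl in a bombesin receptor agonist

The source may hold more compounds than are shown below. What is called first, only, known or untested is meant among the compounds shown, and "the series" means these compounds.

Measured compounds:
compound 1, `CCCCc1cnc(C(CCCC)Cc2ccc(-c3ccccc3C(=O)O)cc2)[nH]1`, 2660 nM
compound 2, `CCCCc1cnc(CCc2ccc(-c3ccccc3C(=O)O)cc2)[nH]1`, 2710 nM
compound 3, `CCCCc1cnc(C(Cc2ccc(-c3ccccc3C(=O)O)cc2)C(C)C)[nH]1`, 4620 nM

Three analogues share a core and have been tested in an in vitro functional assay on cells for agonist activity at Bombesin receptor subtype-3 (Homo sapiens), read by luminescence and calcium flux; a lower number here means that less compound is needed, a higher number that more compound is needed for the effect. Compound 2 stands second highest of the three numbers; compound 1 lies closest to it, with a step of a 1.0-fold higher number from compound 1 to compound 2 (0.01 log units; within the scatter), while compound 3 is furthest, with a step of a 1.7-fold higher number from compound 2 to compound 3 (0.23 log units; within the scatter). The step of a 1.7-fold higher number from compound 1 to compound 3 (0.24 log units; within the scatter) is likewise within the scatter, so the three values cannot be ordered.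

Compound 4, `O=C(O)c1ccccc1-c1ccc(CCc2ncc(CCc3ccccc3)[nH]2)cc1`, has not yet been measured. It differs from compound 2 as follows: phenyl in place of ethyl on a saturated chain carbon, two bonds along the chain from an aromatic carbon. None of the three measured steps touches this part of the molecule; each of them varies the saturated chain carbon bound to an aromatic carbon, and all stayed within the scatter. Among the measured compounds shown here, there is thus no measured step that bears directly on the change, and no basis for expecting a step beyond the scatter in either direction.

The expected step from compound 2 to compound 4 is a 1.0-fold lower number from compound 2 to compound 4 (0.00 log units; within the scatter). Compound 4 is therefore estimated at 2700 nM, with a range from 900 nM to 8000 nM.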

Compound 4, half-maximal effective concentration: 1320 nM
For compound 4 the middle estimate is 2.0-fold (0.31 log units) above the measured one, within the range that was stated.
By their numbers in this assay, from the lowest: compounds 4, 1, 2 and 3 (each within the scatter of the next, the first and the last beyond it).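

Replacing the butyl chain of compound 2 with phenethyl gives a 2.1-fold lower number from compound 2 to compound 4 (0.31 log units; beyond the scatter) in this assay, a modest step but the only one in this set that lies beyond the scatter. The three earlier steps all varied the saturated chain carbon bound to an aromatic carbon, and none of them moved the number beyond the scatter. This result shows that the other end of the molecule, on a saturated chain carbon two bonds along the chain from an aromatic carbon, does respond to change, and that a phenyl can stand there with less compound needed for the effect. Nothing available explains why the number falls with this change.

Going by these compounds, it remains open whether the phenyl ring itself matters or simply the larger group, which a cyclohexyl or a longer chain such as hexyl in the same place would help to separate, and whether benzyl or a pyridine ring would behave like phenethyl. On these data alone, it is also open whether the same change would lower the number on the butyl-branched core of compound 1 or the isopropyl-branched core of compound 3.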